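Replacing vinylcarbonyl with isopropylsulfonyl in compound 2

This account rests on a few compounds, and the source may have more. Where it says the series, first, only, none or still open, it means among the compounds named here.

Measured in an ADME assay on MT4 cells (Homo sapiens) for cytotoxicity, read by MTT assay; on this read-out higher numbers stand for lower toxicity in this test and lower numbers for higher toxicity in this test:
Compound 1 `Cc1cc(C#N)cc(C)c1Oc1ccnc(Nc2ccc(CN3CCCN(S(=O)(=O)C4CC4)CC3)cc2)n1`: "not active" (no number reported)
Compound 2 `C=CC(=O)N1CCN(Cc2ccc(Nc3nccc(Oc4c(C)cc(C#N)cc4C)n3)cc2)CC1`: 7580 nM
Compound 3 `C=CC(=O)N1CCN(Cc2ccc(Nc3nccc(Oc4c(C)cc(/C=C/C#N)cc4C)n3)cc2)CC1`: 5210 nM

Within the data shown here, compound 2 holds one of only two numbers, and the scatter cannot separate them: a 1.5-fold lower number from compound 2 to compound 3 (0.16 log units; within the scatter). That step lies elsewhere on the molecule, so it says little about the change ahead. Compound 4 `Cc1cc(C#N)cc(C)c1Oc1ccnc(Nc2ccc(CN3CCN(S(=O)(=O)C(C)C)CC3)cc2)n1` carries isopropylsulfonyl in place of vinylcarbonyl on an amine nitrogen in a ring. Among the measured compounds shown here, no measured step covers this change. For the measured compounds named here, the only hint is that compound 1, which also bears a sulfonyl group, gave "not active" (no number reported), so a higher number is tentatively expected. The estimated step is a 2.0-fold higher number from compound 2 to compound 4 (0.30 log units; within the scatter). For compound 4 the expected value is 15000 nM, with an estimated range of 5000 nM to 60000 nM.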

Compound 4, half-maximal cytotoxic concentration: 4540 nM
For compound 4 the middle estimate is 3.3-fold (0.52 log units) above the measured one; the measured number lies below the stated range.
By their numbers in this assay, from the lowest: compounds 4, 3 and 2 (each within the scatter of the next).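

In this assay, the change to 4-(isopropylsulfonyl)piperazin-1-yl gives a 1.7-fold lower number from compound 2 to compound 4 (0.22 log units; within the scatter), so at this ring nitrogen the swap of vinylcarbonyl for isopropylsulfonyl does not separate the two compounds. A number in this range therefore does not depend on vinylcarbonyl being present at this position. No supporting data bear on this result, and no cause can be assigned. Open, on these data alone, is whether other groups on the same nitrogen, such as methylsulfonyl or acetyl, would also stay within the scatter of compound 2.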